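The compounds below may be only part of what the source reports. "The series", "measured", "known", "first", "only" and "open" are said of these compounds alone.

Compound 1 `COc1ccccc1-c1cn(C[C@H](O)[C@H]2OC(=O)C(OCc3ccccc3)=C2OCc2ccccc2)nn1` gives in a functional assay on CFPAC-1 cells (Homo sapiens) for antiproliferative activity, read by MTT assay, with a stated time of 72 h (a lower number here means a stronger inhibitor, a higher number a weaker inhibitor), a limit of > 100000 nM.
Compound 2 `C[Si](C)(C)c1cn(C[C@H](O)[C@H]2OC(=O)C(OCc3ccccc3)=C2OCc2ccccc2)nn1` gives in this assay 52600 nM.

Among the compounds with values here, compound 2 holds the only number in this assay. The other value, that of compound 1, is a limit. The step of an at least 1.9-fold lower number from compound 1 to compound 2 (0.27 log units; that floor lies within the scatter) rests on that limit (the limit of > 100000 nM in this assay, at which 1 of the 2 values shown sits). Compound 3 `Cc1ccc(S(=O)(=O)NCc2cn(C[C@H](O)[C@H]3OC(=O)C(OCc4ccccc4)=C3OCc3ccccc3)nn2)cc1` differs from compound 2 by a group of 12 heavy atoms (8 carbon, 1 nitrogen, 2 oxygen, 1 sulfur; one six-membered aromatic ring of carbon only) in place of a group of 4 heavy atoms (3 carbon, 1 silicon; no ring), on an aromatic carbon. Within the data shown here, only the step from compound 1 to compound 2 bears on this change, and its floor lies within the scatter, so no lower number is expected from adding a larger aromatic group on that carbon. Compound 3 is therefore expected to give in this assay about 70000 nM, between 30000 nM and 150000 nM, with a fair chance that only a limit is reported. The expected step is a 1.3-fold higher number from compound 2 to compound 3 (0.12 log units; within the scatter), within the scatter.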

Compound 3, half-maximal inhibitory concentration: 68000 nM
Compound 3: the middle estimate sits 1.0-fold (0.01 log units) above what was measured; the measured number falls inside the stated range.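

In this assay, compound 3, with (((4-methylphenyl)sulfonyl)amino)methyl and its hydrogen-bond donor and acceptors on this aromatic carbon, stands within the scatter of compound 2 (a 1.3-fold higher number from compound 2 to compound 3 (0.11 log units; within the scatter)). Compound 1 stands only at a limit (> 100000 nM). The other comparison (an at least 1.4-fold lower number from compound 1 to compound 3 (0.16 log units; that floor lies within the scatter)) has a floor within the scatter, so it sets no order among these groups either. Still open is whether an amine or a carboxylic acid on this carbon would bring the number clearly below those shown, and whether any group here can.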